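The source may hold more compounds than are shown below. What is called first, only, known or untested is meant among the compounds shown, and "the series" means these compounds.

Among the compounds with values here, compound 1 `Cc1ccc(CO/N=C/c2c(C)nn(C)c2Oc2ccc(Cl)cc2)cc1` gives 30.7% in a functional assay on MCF7 cells (Homo sapiens) for antiproliferative activity, tested at 1 uM (a higher number here means more inhibition at the concentration tested (going by the name of the read-out), a lower number less inhibition), the lowest of the two numbers measured, though its nearest neighbour compound 2 `CCOC(=O)c1ccc(CO/N=C/c2c(C)nn(C)c2Oc2ccc(Cl)cc2)cc1`, which gives 33.9%, lies within the scatter; the only measured step, a number 3.2 percentage points higher from compound 1 to compound 2 (within the scatter), concerns a different position. Compound 3 `Cc1ccc(CO/N=C/c2c(C)nn(C)c2Oc2ccccc2)cc1` differs from compound 1 by hydrogen in place of chloro on an aromatic carbon. Within the data shown here, no measured step touches this position, so the data give no direction; the step from compound 1 to compound 3 is expected to be a number 2.7 percentage points lower from compound 1 to compound 3 (within the scatter), not beyond the scatter. Compound 3 is therefore estimated at 28% in this assay, between 12% and 44%.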

Compound 3, a percentage reported as inhibition, at one concentration (the size of the read-out at that concentration, not a potency): 38.2%
For compound 3 the middle estimate is 10.2 percentage points below the measured one; the measured number falls inside the stated range.
By their numbers in this assay, from the lowest: compounds 1, 2 and 3 (each within the scatter of the next).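

Going from 4-chlorophenoxy to phenoxy gives a number 7.5 percentage points higher from compound 1 to compound 3 (within the scatter) in this assay, so this first look at the position shows that the read-out holds within the scatter when the chloro gives way to hydrogen. At this concentration, the chloro is therefore not needed for the inhibition seen with compound 1. Nothing available explains the size of this step. As far as these compounds go, it remains open whether a methoxy group or an amine at this place would move the number beyond the scatter. From the compounds shown here alone, it also remains open whether the same change would give a similar step on compound 2.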